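Compound 3 to compound 4: a new alkene amide

A few compounds are considered here, and "the series" means these few. Any claim that something is new, unique, unknown or untested is made for them only; others in the source may bear on it.

Compound 1 `CNC(=O)/C(C)=C/c1ccc(NC(=O)Nc2ccc(Cl)c(C(F)(F)F)c2)cc1`: > 50000 nM, a limit and not a number
Compound 2 `CNC(=O)c1cccc(-c2ccc(NC(=O)Nc3ccc(Cl)c(C(F)(F)F)c3)cc2)c1`: 46500 nM
Compound 3 `CNC(=O)CCc1ccc(NC(=O)Nc2ccc(Cl)c(C(F)(F)F)c2)cc1`: 25200 nM

Going by the values given here, in a functional assay on A-375 cells (Homo sapiens) for inhibition, read by MTT assay, with a stated time of 120 h (on this read-out lower numbers stand for stronger inhibition and higher numbers for weaker inhibition), compound 3 gives 25200 nM, and the only other true number is close to it: a 1.8-fold lower number from compound 2 to compound 3 (0.27 log units; within the scatter). Compound 4 `CNC(=O)/C=C(\C)c1ccc(NC(=O)Nc2ccc(Cl)c(C(F)(F)F)c2)cc1` carries 1-methyl-2-(methylcarbamoyl)ethenyl in place of 2-(methylcarbamoyl)ethyl on an aromatic carbon. The nearest measured change is the side chain of compound 1, which also has a double bond, and that step is an at least 1.9-fold lower number from compound 1 to compound 3 (0.29 log units; that floor lies within the scatter). Neither step points to a large effect, so little change beyond the scatter is expected, perhaps a slightly higher number. The expected step is a 1.3-fold higher number from compound 3 to compound 4 (0.10 log units; within the scatter). The estimate for compound 4 is 32000 nM, with an expected range of 15000 nM to 50000 nM.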

Compound 4, half-maximal inhibitory concentration: > 50000 nM
Compound 4: only a limit was reported (the forecaster's own chance of this, stated with the estimate: 35%); middle value at least 1.5-fold (0.19 log units) from the limit.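

In this assay, 1-methyl-2-(methylcarbamoyl)ethenyl in place of 2-(methylcarbamoyl)ethyl gives an at least 1.9-fold higher number from compound 3 to compound 4 (0.29 log units; that floor lies within the scatter). In place of 3-(methylcarbamoyl)phenyl, the same group gives an at least 1.0-fold higher number from compound 2 to compound 4 (0.03 log units; that floor lies within the scatter). Compound 4 gives only a limit, so both steps are floors, and no side chain at this position has yet given a value clearly apart from the others.

On these data alone, the step between compound 1 and compound 4 cannot be read, because both compounds stand at a limit: the limit of > 50000 nM in this assay, at which 2 of the 4 values shown sit. Whether an amine or a carboxylic acid in place of the methylcarbamoyl end of the chain would give stronger inhibition stays open.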